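A New Ring Group on Compound 1

The source may hold more compounds than are shown below. What is called first, only, known or untested is meant among the compounds shown, and "the series" means these compounds.

In a functional assay on A2780 cells (Homo sapiens) for inhibition (a lower number here means a stronger inhibitor, a higher number a weaker inhibitor), compound 1 `CC(C(=O)Nc1cc(C2CC2)[nH]n1)c1ccc(N2C(=O)CCC2C)cc1` gives 6400 nM. That places it in the middle of the three measured compounds: compound 2 `C[C@H](C(=O)Nc1cc(C2CC2)[nH]n1)c1ccc(N2CCNC2=O)cc1` reads lower at 1270 nM, and compound 3 `CC(C(=O)Nc1cc(C2CC2)[nH]n1)c1ccc(N2C(=O)CCC2c2ccccc2)cc1` reads higher at 15300 nM.

Compound 4 `CC(C(=O)Nc1cc(C2CC2)[nH]n1)c1ccc(N2CCC(C(N)=O)C2=O)cc1` keeps the core of compound 1 but changes the group on an aromatic carbon, para to a large group: a group of 9 heavy atoms (5 carbon, 2 nitrogen, 2 oxygen; one five-membered non-aromatic ring with 1 hetero atom) in place of a group of 7 heavy atoms (5 carbon, 1 nitrogen, 1 oxygen; one five-membered non-aromatic ring with 1 hetero atom), on an aromatic carbon. Among the compounds with values here, one measured step touches this group directly: a 2.4-fold higher number from compound 1 to compound 3 (0.38 log units; beyond the scatter), with phenyl in place of methyl on a saturated ring carbon. That step is modest, though beyond the scatter. Compound 2, which carries a different ring at the same place, shows a lower number at 1270 nM. Neither comparison matches the new group, so the direction rests on thin evidence. Only a small step toward a lower number is expected, a 1.6-fold lower number from compound 1 to compound 4 (0.20 log units; within the scatter). For compound 4 the estimated value is 4000 nM, with an expected range from 1200 nM to 13000 nM.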

Compound 4, half-maximal inhibitory concentration: 5710 nM
Compound 4: the middle estimate sits 1.4-fold (0.15 log units) below what was measured, and the stated range covers the measured number.
By their numbers in this assay, from the lowest: compound 2; then compounds 4 and 1 (each within the scatter of the next); then compound 3.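

In the cell assay (this assay), replacing the group of 7 heavy atoms with the group of 9 heavy atoms on this aromatic carbon gives a step too small to separate the two compounds (a 1.1-fold lower number from compound 1 to compound 4 (0.05 log units; within the scatter)). The earlier step at this place, phenyl in place of methyl on a saturated ring carbon, moved the number beyond the scatter (a 2.4-fold higher number from compound 1 to compound 3 (0.38 log units; beyond the scatter)), whereas this change, which brings in 1 hydrogen-bond donor where the old group had 0, does not. Nothing measured here gives a reason for this result.

From the compounds shown here alone, it remains open whether an amine or a carboxylic acid on the same five-membered ring would move the number beyond the scatter. A longer chain at that ring carbon is equally untested by the compounds shown here.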